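Nitro in Place of Chloro: What to Expect for Compound 4

The source may hold more compounds than are shown below. What is called first, only, known or untested is meant among the compounds shown, and "the series" means these compounds.

Compound 1, `CCOc1ccccc1Nc1nc(SCc2ccc(C(F)(F)F)cc2)nc2ccccc12`, gives > 50000 nM in a functional assay on HGC-27 cells (Homo sapiens) for cytotoxicity, read by MTT assay, with a stated time of 72 h; a higher number here means a weaker inhibitor, a lower number a stronger inhibitor; this value is a limit of the assay, not a number.
Compound 2, `FC(F)(F)c1ccc(CSc2nc(Nc3cccc(Cl)c3)c3ccccc3n2)cc1`, gives 19900 nM in this assay.
Compound 3, `FC(F)(F)c1ccc(CSc2nc(Nc3ccc(Cl)cc3)c3ccccc3n2)cc1`, gives 14100 nM in this assay.

Compound 3 stands at the lowest of the two numbers measured, with compound 2 nearest; the step of a 1.4-fold lower number from compound 2 to compound 3 (0.15 log units; within the scatter) lies within the scatter, so the two cannot be put in an order. The steps of an at least 2.5-fold lower number from compound 1 to compound 2 (0.40 log units; beyond the scatter) and an at least 3.5-fold lower number from compound 1 to compound 3 (0.54 log units; beyond the scatter) reach beyond the scatter, yet both start from a limit, (the limit of > 50000 nM in this assay, at which 1 of the 3 values shown sits), so their true size is only a lower bound.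

Compound 4, `O=[N+]([O-])c1ccc(Nc2nc(SCc3ccc(C(F)(F)F)cc3)nc3ccccc23)cc1`, differs from compound 3 in one place: nitro in place of chloro on an aromatic carbon. Within the data shown here, none of the measured steps exchanges a chloro for a nitro; the steps seen so far replace the whole 2-ethoxyphenyl group or move a chloro from one position to another. There is therefore no direct guide to this change, and no step beyond the scatter is expected. Compound 4 is expected to give about 14000 nM in this assay, within a range from 5000 nM to 40000 nM. This estimate means an expected step of a 1.0-fold lower number from compound 3 to compound 4 (0.00 log units; within the scatter), staying within the scatter.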

Compound 4, half-maximal inhibitory concentration: 16600 nM
Compound 4: the middle estimate sits 1.2-fold (0.07 log units) below what was measured, and the stated range covers the measured number.
By their numbers in this assay, from the lowest: compounds 3, 4 and 2 (each within the scatter of the next). At a limit, above all of these: compound 1.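

Of the changes shown, only the exchange of chloro for nitro keeps the 4-substituted phenyl ring and alters just the group on it, replacing one heavy atom with three and adding two hydrogen-bond acceptors, yet in this assay it gives a 1.2-fold higher number from compound 3 to compound 4 (0.07 log units; within the scatter), so this position accepts the larger nitro group with no change that can be read. The comparison with the 3-chlorophenyl compound gives a 1.2-fold lower number from compound 2 to compound 4 (0.08 log units; within the scatter), so compounds 2, 3 and 4 cannot be put in an order and form one group within the scatter. Compound 1 carries a limit and not a number, so an at least 3.0-fold lower number from compound 1 to compound 4 (0.47 log units; beyond the scatter) sets only a lower bound on the true size of that step: the limit of > 50000 nM in this assay, at which 1 of the 4 values shown sits.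

As far as these compounds go, it remains open whether an amine or a carboxylic acid in place of the chloro on this ring would give a step beyond the scatter, or would also leave the number where it is. The compounds shown also leave open how the number responds to a change on the trifluoromethyl-bearing side of the molecule, which is the same in all four.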